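The compounds below may be only part of what the source reports. "The series", "measured", "known", "first", "only" and "open" are said of these compounds alone.

In a functional assay on A498 cells (Homo sapiens) for inhibition, read by sulforhodamine B assay, with a stated time of 48 h (on this read-out lower numbers stand for stronger inhibition of growth and higher numbers for weaker inhibition of growth), compound 1 `O=C(Nc1cccc(-n2cc(-c3ccncc3)c(-c3ccc(Cl)c(O)c3)n2)c1)Nc1cccc(C(F)(F)F)c1` gives > 32500 nM as its reading, which is a limit of the assay and not a number. Compound 2 `COc1cc(-c2nn(-c3cccc(NC(=O)Nc4cccc(C(F)(F)F)c4)c3)cc2-c2ccncc2)ccc1Cl` gives a measured 4040 nM in the same test. For the measured compounds named here, the one measured step of an at least 8.0-fold lower number from compound 1 to compound 2 (0.90 log units; beyond the scatter) comes from methyl in place of hydrogen on an oxygen on an aromatic ring, and it is the only guide to how far a single change can move compound 1 here. Compound 3 `O=C(Nc1cccc(-n2cc(-c3ccncc3)c(-c3ccc(Cl)c(O)c3)n2)c1)Nc1ccc(Cl)c(C(F)(F)F)c1` carries another change chloro in place of hydrogen on an aromatic carbon with chloro in place of hydrogen on an aromatic carbon, ortho to a trifluoromethyl group and para to a large group. Going by the values given here, no measured step shows this change directly. In this assay compound 3 is expected to show a smaller shift toward stronger inhibition, an estimated at least 2.3-fold lower number from compound 1 to compound 3 (0.36 log units; beyond the scatter) in all. The expected value for compound 3 is 14000 nM within an estimated range from 4000 nM to 32500 nM in this test.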

Compound 3, concentration for total growth inhibition: 6900 nM
Compound 3: middle estimate off by 2.0-fold (0.31 log units), on the high side; the range from low to high includes it.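

In this assay, chloro in place of hydrogen on an aromatic carbon of the 3-(trifluoromethyl)phenyl group, ortho to a trifluoromethyl group and para to a large group, gives an at least 4.7-fold lower number from compound 1 to compound 3 (0.67 log units; beyond the scatter). This shows a second place on compound 1, away from the aromatic oxygen that carries the methyl in compound 2, where one change brings the reading from a limit of the assay to a measured number. The size of this step is only a lower bound, since compound 1 has a limit and not a number: the limit of > 32500 nM in this assay, at which 1 of the 3 values shown sits.

The compounds shown leave open whether fluoro, methyl or an amine on this same carbon would move the reading as chloro does. As far as these compounds go, it also remains open how chloro on this carbon and methyl on the aromatic oxygen would act together in one compound.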